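A few compounds are considered here, and "the series" means these few. Any claim that something is new, unique, unknown or untested is made for them only; others in the source may bear on it.

Of the compounds shown here, three with a shared core have been measured so far in an ADME assay on microsomes from liver (Mus musculus) for metabolic stability, with a stated time of 30 min (on this read-out lower numbers stand for a less stable compound and higher numbers for a more stable compound), and they differ in the group on an aromatic nitrogen. With ethyl there, compound 1 `CCn1cc(Nc2ncc(Cl)c(N[C@H]3[C@@H](C(N)=O)[C@@H]4C=C[C@H]3C4)n2)cn1` has 13% left. With piperidin-3-yl, compound 2 `NC(=O)[C@@H]1[C@H](Nc2nc(Nc3cnn([C@@H]4CCCNC4)c3)ncc2Cl)[C@H]2C=C[C@@H]1C2` has 48% left. With carbamoylmethyl, compound 3 `NC(=O)Cn1cc(Nc2ncc(Cl)c(N[C@H]3[C@@H](C(N)=O)[C@@H]4C=C[C@H]3C4)n2)cn1` has 68% left, the highest of the three numbers.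

Compound 4 `NC(=O)[C@@H]1[C@H](Nc2nc(Nc3cnn(CC(=O)O)c3)ncc2Cl)[C@H]2C=C[C@@H]1C2` has not been measured yet. It has hydroxy in place of amino on a carbonyl carbon, which turns carbamoylmethyl into carboxymethyl.

Two measured steps end at compound 3 and bear on this group. The data show a number 55 percentage points higher from compound 1 to compound 3 (beyond the scatter) and also a number 20 percentage points higher from compound 2 to compound 3 (beyond the scatter) when that group is changed. Neither step swaps amino for hydroxy, so neither measures this change directly. Compound 4 keeps the carbonyl and the chain of compound 3, and a move smaller than the modest a number 20 percentage points higher from compound 2 to compound 3 (beyond the scatter) is therefore expected. In this assay the expected result is a number 4 percentage points higher from compound 3 to compound 4 (within the scatter) and not a large move in either direction. For compound 4 the estimate is 72% left, expected to fall between 50% and 92% in a repeat measurement.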

Compound 4, percent of the compound remaining: > 95%
Compound 4 ended at the assay's limit; the forecaster's own chance of this, stated with the estimate: 3%; middle value at least 23 percentage points from the limit.
By their numbers in this assay, from the lowest: compound 1; then compound 2; then compound 3. At a limit, above all of these: compound 4.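

Compound 4 stands at a limit of this assay, not at a number: the limit of > 95% in this assay, at which 1 of the 4 values shown sits. The earlier compounds shown here differ in the whole group on the aromatic nitrogen, whereas here one atom changes, hydroxy in place of amino on a carbonyl carbon, with the chain and the carbonyl kept, and this gives a number at least 27 percentage points higher from compound 3 to compound 4 (beyond the scatter), so even so small an exchange at this position can move the read-out beyond the scatter. Carboxymethyl also stands clear of the other two groups, with a number at least 47 percentage points higher from compound 2 to compound 4 (beyond the scatter) and a number at least 82 percentage points higher from compound 1 to compound 4 (beyond the scatter), which places it first among the four groups shown on this nitrogen.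

How far compound 4 lies past the limit stays unknown, so the true size of these steps is open, and nothing shown explains why the exchange has this effect. From the compounds shown here alone, it is also open whether the result holds for a methyl ester on the same chain or for a carboxylic acid on a longer chain, either of which would show how much depends on the free carboxy group and its distance from the aromatic nitrogen.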